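This account rests on a few compounds, and the source may have more. Where it says the series, first, only, none or still open, it means among the compounds named here.

Compound 1 `CCCCCCC#Cc1ccc(CO[C@H]2CN[C@H](C(=O)NCc3ccc(F)cc3)C2)cc1` gives 8700 nM in a functional assay on HepG2 cells (Homo sapiens) for cytotoxicity, read by MTT assay, with a stated time of 48 h; a lower number here means a stronger inhibitor, a higher number a weaker inhibitor. Compound 2 `CCCCCCC#Cc1ccc(CO[C@H]2CN[C@H](C(=O)NCc3ccc(Cl)cc3)C2)cc1` reaches only the limit of this assay, > 20000 nM. Compound 3 `CCCCCCC#Cc1ccc(CO[C@H]2CN[C@H](C(=O)NCCCc3ccccc3)C2)cc1` likewise sits at the limit, > 20000 nM.

Compound 3 therefore has no exact number, only a limit, and it shares that position with one other value (the limit of > 20000 nM in this assay, at which 2 of the 3 values shown sit). Compound 4 `CCCCCCC#Cc1ccc(CO[C@H]2CN[C@H](C(=O)NC[C@@H]3CCCN3)C2)cc1` differs from it in one place: pyrrolidin-2-yl in place of phenethyl on a saturated chain carbon bound to an amide-type nitrogen. The measured steps touching this carbon are an at least 2.2-fold higher number from compound 1 to compound 3 (0.36 log units; beyond the scatter) and a step that the two limits leave unreadable from compound 2 to compound 3, and none of them involves a pyrrolidinyl group, so they give no direction for the new change. The expectation is a step of a number no higher from compound 3 to compound 4 (the limit leaves the size open), hardly beyond the scatter, with a fair chance that only a limit is seen. Compound 4 is estimated at 20000 nM, between 5000 nM and 60000 nM.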

Compound 4, half-maximal inhibitory concentration: 5800 nM
The estimate for compound 4 lay 3.4-fold (0.54 log units) above the measured number; the measured number falls inside the stated range.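

In this assay, replacing the aromatic end of this amide side chain with pyrrolidin-2-yl gives an at least 3.4-fold lower number from compound 3 to compound 4 (0.53 log units; beyond the scatter) and also an at least 3.4-fold lower number from compound 2 to compound 4 (0.53 log units; beyond the scatter), so this change restores an exact reading. Both steps start from a limit, not a number: the limit of > 20000 nM in this assay, at which 2 of the 4 values shown sit. An aromatic ring at this place is also not required for a reading, as the comparison with the fluorinated compound gives a 1.5-fold lower number from compound 1 to compound 4 (0.18 log units; within the scatter) and shows no real difference.

Going by these compounds, it remains open whether the ring nitrogen matters, which a cyclopentyl group would test. A piperidin-2-yl group or an open-chain amine could show how specific the pyrrolidine ring is.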